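This account rests on a few compounds, and the source may have more. Where it says the series, first, only, none or still open, it means among the compounds named here.

In a functional assay on a cell-free system (plasma, Oryctolagus cuniculus) for inhibition, with stated times of 5 min, 1 min and 6 min (a lower number here means a stronger inhibitor, a higher number a weaker inhibitor), compound 1 `CCOC(=O)c1c(C)nc(-c2cccc(C#N)c2)n1OC(C)C` gives 6740 nM. Compound 2 `CCOC(=O)c1c(C)nc(-c2cccc(C#N)c2)n1OCCC(=O)O` gives only a limit, > 30000 nM, and not a number. This is the limit of > 30000 nM in this assay, at which 1 of the 2 values shown sits, so the position of compound 2 is bounded on one side only.

Compound 3 `CCOC(=O)c1c(C)nc(-c2cccc(C#N)c2)n1OCc1ccncc1` keeps the shared core and differs from compound 2 in the chain on the oxygen: pyridin-4-yl in place of carboxymethyl on a saturated chain carbon bound to an oxygen on an aromatic ring. Pyridin-4-yl thus stands in place of carboxymethyl on a saturated chain carbon bound to an oxygen on an aromatic ring.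

Among the compounds with values here, only one measured step bears on this change: an at least 4.4-fold higher number from compound 1 to compound 2 (0.64 log units; beyond the scatter). That step introduced the group now leaving, so its removal is expected to recover a similar amount, towards a lower number in this assay. Within the data shown here, the entering ring has no measured precedent here, and the true size of the step remains open. The estimated change is an at least 5.0-fold lower number from compound 2 to compound 3 (0.69 log units; beyond the scatter). For compound 3 the expected value is 6000 nM, within an estimated range of 1500 nM to 25000 nM.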

Compound 3, half-maximal inhibitory concentration: 6200 nM
Compound 3: middle estimate off by 1.0-fold (0.01 log units), on the low side; the measured number falls inside the stated range.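

Placing pyridin-4-yl in place of carboxymethyl on a saturated chain carbon bound to an oxygen on an aromatic ring gives an at least 4.8-fold lower number from compound 2 to compound 3 (0.68 log units; beyond the scatter) in this assay, so the loss seen with the acid-bearing chain does not extend to every larger group at this position. The value of compound 2 is a limit and not a number, so this step is bounded on one side only: the limit of > 30000 nM in this assay, at which 1 of the 3 values shown sits. The step with (pyridin-4-yl)methyl in place of isopropyl on an oxygen on an aromatic ring is a 1.1-fold lower number from compound 1 to compound 3 (0.04 log units; within the scatter), which means that in this assay these two groups cannot be told apart, and this position tolerates an aromatic ring on the chain as well as it does isopropyl.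

The compounds shown do not tell whether the free carboxylic acid or the chain that carries it sets compound 2 apart, a question that a methyl ester or a primary amide on the same 2-carboxyethyl chain would address. Nor do they tell whether the nitrogen of the pyridin-4-yl ring matters, which a plain benzyl group or a pyridin-3-ylmethyl group on the same oxygen would test.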